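Chain shortening in the aminoglycoside-like ether series

This account rests on a few compounds, and the source may have more. Where it says the series, first, only, none or still open, it means among the compounds named here.

Measured so far:
- compound 1 `CCCCCCCCCO[C@@H]1[C@@H](N)[C@@H](O[C@H]2[C@H](O)[C@@H](OCCCCCCCCC)[C@H](N)C[C@@H]2N)O[C@H](CN)[C@H]1O`: 67.4% in an ADME assay on J774 cells (Mus musculus) for cytotoxicity, read by MTT assay, with a stated time of 24 h, tested at 30 uM; a lower number here means a stronger effect, a higher number a weaker effect of the compound at the concentration tested
- compound 2 `CCCCCCCCCCCO[C@@H]1[C@@H](O)[C@H](O[C@H]2O[C@H](CN)[C@@H](O)[C@H](OCCCCCCC)[C@H]2N)[C@@H](N)C[C@H]1N`: 38.8% in this assay

Compound 2 holds the lowest of the two numbers in this assay; compound 1 sits higher by a gap beyond the usual scatter, so compound 2 shows the stronger effect of the pair at the tested concentration.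

Compound 3 `CCCCCCCO[C@@H]1[C@@H](N)[C@@H](O[C@H]2[C@H](O)[C@@H](OCCCCCCC)[C@H](N)C[C@@H]2N)O[C@H](CN)[C@H]1O` has not yet been measured in this assay. It is reached from compound 2 by one change: hydrogen in place of butyl on a saturated chain carbon, seven bonds along the chain from an oxygen on a saturated carbon. Among the compounds with values here, no step between measured compounds covers this change, and the two measured numbers give no step that isolates chain length alone, since compound 1 and compound 2 differ in several places.

Within the data shown here, with no comparable step known, the expectation for compound 3 is a move away from the strong effect of compound 2, toward the weaker end, by an amount beyond the scatter: the expected step of a number 31.2 percentage points higher from compound 2 to compound 3 (beyond the scatter). Compound 3 is therefore estimated at 70% in this assay, with a range from 50% to 92%.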

Compound 3, a percentage reported as activity, at one concentration (the size of the read-out at that concentration, not a potency): 79.9%
The estimate for compound 3 lay 9.9 percentage points below the measured number; measured number inside the range.
By their numbers in this assay, from the lowest: compound 2; then compound 1; then compound 3.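

Within the data shown here, the step of a number 41.1 percentage points higher from compound 2 to compound 3 (beyond the scatter) in this assay is the first comparison that rests on a single change, and it is large and beyond the scatter. It shows that this place on the chain matters: hydrogen in place of butyl on a saturated chain carbon, seven bonds along the chain from an oxygen on a saturated carbon, takes the compound from the stronger effect to a clearly weaker one at the tested concentration. The two earlier numbers could not show this, since compound 1 and compound 2 differ in several places, and nothing at hand explains the size of the step.

As far as these compounds go, one step gives two end points and no trend, so it remains open whether the number moves gradually as the chain is cut back or changes abruptly at some chain length. From the compounds shown here alone, it is also open whether a longer chain at this place, or an amine carried on the chain in place of butyl, would give a number near that of compound 2 or near that of compound 3.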